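The source may report more compounds than this note shows. Statements on the series, on what has been measured and on what is new or still open speak of the compounds shown alone.

Compound 1 `CCCc1c(COc2ccc(C(=O)C(C)Cc3nnn[nH]3)cc2)ccc(C(C)=O)c1O`: 9.2 mg/kg
Compound 2 `CCc1c(COc2ccc(C(=O)CC(C)(C)CC(=O)O)cc2)ccc(C(C)=O)c1O`: 1.4 mg/kg
Compound 3 `CCc1c(COc2ccc(C(=O)CC(C)(C)Cc3nnn[nH]3)cc2)ccc(C(C)=O)c1O`: 1.1 mg/kg

All three were tested in an in vivo functional assay on the whole organism (Rattus norvegicus) with cysteinyl leukotriene receptor (Homo sapiens) as the target; on this read-out lower numbers stand for an effect already at smaller amounts and higher numbers for an effect only at larger amounts of compound. Compound 1 stands highest of the three numbers there; compound 2 gives 1.4 mg/kg and compound 3 gives 1.1 mg/kg, both well apart from compound 1, but each of these two differs from compound 1 in more than one place, so their gap to compound 1 cannot be tied to a single change. Among the compounds with values here, the only single-point step among the measured compounds, a 1.3-fold lower number from compound 2 to compound 3 (0.10 log units; within the scatter), exchanges the acid for the tetrazole and lies within the scatter.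

Compound 4 `CCCc1c(COc2ccc(C(=O)CCCCc3nnn[nH]3)cc2)ccc(C(C)=O)c1O` differs from compound 1 in one place: 4-(1H-tetrazol-5-yl)butyl in place of 1-((1H-tetrazol-5-yl)methyl)ethyl on a carbonyl carbon. The tetrazole is kept; what changes is the chain that carries it, losing its branch and gaining length. Within the data shown here, no measured step touches the length or branching of this chain, so the data give no direction for the step in this assay. The step of a 1.3-fold lower number from compound 2 to compound 3 (0.10 log units; within the scatter) shows only that the tetrazole itself is tolerated much as the acid is. Compound 4 is therefore expected near compound 1, with no step beyond the scatter but a wide range: the estimate for compound 4 is 7 mg/kg, between 2.5 mg/kg and 20 mg/kg, meaning an expected step of a 1.3-fold lower number from compound 1 to compound 4 (0.12 log units; within the scatter).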

Compound 4, dose for half-maximal effect: 2.4 mg/kg
For compound 4 the middle estimate is 2.9-fold (0.46 log units) above the measured one, and the stated range ends above it.
By their numbers in this assay, from the lowest: compounds 3, 2 and 4 (each within the scatter of the next, the first and the last beyond it); then compound 1.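

In this assay, within the data shown here, putting 4-(1H-tetrazol-5-yl)butyl in place of 1-((1H-tetrazol-5-yl)methyl)ethyl on a carbonyl carbon gives a 3.8-fold lower number from compound 1 to compound 4 (0.58 log units; beyond the scatter) and is the first single-place change to reach beyond the scatter. The tetrazole is present on both sides and only the chain carrying it differs, which shows that the read-out responds to the shape of this chain. Among these compounds, the only earlier single-place step, a 1.3-fold lower number from compound 2 to compound 3 (0.10 log units; within the scatter), exchanged the carboxylic acid for the tetrazole and left the chain untouched, and nothing at hand bears on the reason for the new step.

The step removes the branch and extends the chain at once, so the compounds shown leave open whether the loss of the branch, the added length or both carry the change, and a straight propyl or pentyl chain bearing the tetrazole would be needed to separate them. As far as these compounds go, it also remains open whether a carboxylic acid on the butyl chain of compound 4 would stay as close to the tetrazole as it does in the pair of compound 2 and compound 3.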